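Aryl ether variation on the shared core: clearance notes

The compounds below may be only part of what the source reports. "The series", "measured", "known", "first", "only" and "open" are said of these compounds alone.

Measured compounds:
compound 1, `CC(C)COc1ncc(-c2cc(F)c(-c3nnc(S(=O)(=O)CC4CC4)[nH]3)cc2F)cc1Cl`, 67 uL/min
compound 2, `Cc1ccc(Cl)c(Oc2ncc(-c3cc(F)c(-c4nnc(S(=O)(=O)CC5CC5)[nH]4)cc3F)cc2Cl)c1`, 41 uL/min

In an ADME assay on microsomes from liver (Homo sapiens) for metabolic stability (a higher number here means faster removal of the compound, a lower number slower removal), compound 1 gives 67 uL/min and compound 2 gives 41 uL/min. Compound 2 stands beside compound 1 on these two numbers, the pair within the scatter of each other, as the change a 1.6-fold lower number from compound 1 to compound 2 (0.21 log units; within the scatter) shows. That step replaced isobutyl with 2-chloro-5-methylphenyl on an oxygen on an aromatic ring without moving the number beyond the scatter.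

Compound 3, `O=S(=O)(CC1CC1)c1nnc(-c2cc(F)c(-c3cnc(Oc4ccccc4C(F)(F)F)c(Cl)c3)cc2F)[nH]1`, is not yet measured in this assay. It differs from compound 2 as follows:
2-(trifluoromethyl)phenyl in place of 2-chloro-5-methylphenyl on an oxygen on an aromatic ring

Going by the values given here, the only measured step touching this position is the one from compound 1 to compound 2, and it stayed within the scatter. Among the compounds with values here, no measured pair exchanges one aryl group for another on this oxygen, so there is nothing to point to a direction. The expectation is therefore a step of a 1.0-fold higher number from compound 2 to compound 3 (0.01 log units; within the scatter), not beyond the scatter. Compound 3 is estimated at 42 uL/min, with a range from 20 uL/min to 85 uL/min.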

Compound 3, intrinsic clearance in a liver preparation (reported as CLH), per the amount of preparation that the assay uses: < 14 uL/min
Compound 3 gave a limit, no number; the forecaster's own chance of this, stated with the estimate: 5%; middle value at least 3.0-fold (0.47 log units) away from the limit.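

On this oxygen, the identity of the aryl group matters in this assay: 2-(trifluoromethyl)phenyl in place of 2-chloro-5-methylphenyl gives an at least 2.9-fold lower number from compound 2 to compound 3 (0.46 log units; beyond the scatter), and this aryl-for-aryl exchange shows a change beyond the scatter at a position where the earlier step had not. Set against isobutyl, the same aryl group gives an at least 4.7-fold lower number from compound 1 to compound 3 (0.67 log units; beyond the scatter), whereas a 1.6-fold lower number from compound 1 to compound 2 (0.21 log units; within the scatter) stays within the scatter, so among these compounds an aryl group on this oxygen does not by itself separate the values, and the outcome depends on which aryl group is present. For compound 3 the read-out is a limit and not a number, and both new steps are therefore minimum sizes: the limit of < 14 uL/min in this assay, at which 1 of the 3 values shown sits.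

The exchange removes the chloro and methyl substituents and adds trifluoromethyl in a single step, and the compounds shown do not separate these parts. As far as these compounds go, whether an unsubstituted phenyl or a methoxyphenyl group on this oxygen would fall with compound 2 or with compound 3 remains open.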